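A few compounds are considered here, and "the series" means these few. Any claim that something is new, unique, unknown or untested is made for them only; others in the source may bear on it.

Working notes on the series. Compound 1 `CC(=O)OCCOn1cnc2c(Cl)nc(N)nc21` and compound 2 `CC(=O)OCCOn1cnc2c(Cl)nc(I)nc21` share one core. In a functional assay on CCRF-CEM cells (Homo sapiens) for inhibition (a higher number here means a weaker inhibitor, a lower number a stronger inhibitor), compound 1 gives only a limit of the assay, > 500000 nM; this is the limit of > 500000 nM in this assay, at which 1 of the 2 values shown sits. Going by the values given here, compound 2 gives 11000 nM in this assay, and the step of an at least 45-fold lower number from compound 1 to compound 2 (1.65 log units; beyond the scatter) is the only measured step in the set. Compound 3 `CC(=O)OCCOn1cnc2c(S)nc(N)nc21` has not been measured. It differs from compound 1 in one place: sulfanyl in place of chloro on an aromatic carbon. Among the compounds with values here, no measured step touches the chloro position; the step from compound 1 to compound 2 changes a different group, so it offers no direct guide for this change. With compound 1 standing only at a limit, the step of a number no higher from compound 1 to compound 3 (the limit leaves the size open) is expected to be small or not resolvable within the scatter. Compound 3 is estimated at 500000 nM, with a range from 100000 nM to 2000000 nM, and a further limit is expected to be the most likely outcome.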

Compound 3, half-maximal inhibitory concentration: 7500 nM
Compound 3: middle estimate off by 67-fold (1.82 log units), on the high side; measured number outside the range, below it.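

In this assay, an at least 66-fold lower number from compound 1 to compound 3 (1.82 log units; beyond the scatter) shows that the chloro position is not silent: with the amino group kept, sulfanyl in place of chloro on an aromatic carbon is enough on its own to give a measurable value. The earlier step had shown such a change only at the amino position, so the shared core now responds at two separate places. Compound 1 stands at a limit, so the full size of this step stays open: the limit of > 500000 nM in this assay, at which 1 of the 3 values shown sits.

The compounds shown leave open whether a hydroxyl, a methylsulfanyl group or an amine in this place would give a similar number, or whether the change is particular to sulfanyl. They also leave open what sulfanyl would give alongside the iodo group of compound 2.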